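The source may hold more compounds than are shown below. What is called first, only, known or untested is meant among the compounds shown, and "the series" means these compounds.

Compound 1 `O=C(c1cc(Cc2n[nH]c(=O)c3ccccc23)ccc1F)N1CCc2nc(Cl)ncc2C1` has no result in a functional assay on MDA-MB-231 cells (Homo sapiens) for inhibition, read by MTT assay, with a stated time of 48 h; a higher number here means a weaker inhibitor, a lower number a stronger inhibitor ("nd" (no result reported)). Compound 2 `CCN1CCN(c2ncc3c(n2)CCN(C(=O)c2cc(Cc4n[nH]c(=O)c5ccccc45)ccc2F)C3)CC1` reaches only the assay limit, > 200000 nM, in this assay. Compound 3 `CN(C)CCN(C)c1ncc2c(n1)CCN(C(=O)c1cc(Cc3n[nH]c(=O)c4ccccc34)ccc1F)C2` likewise reaches only the assay limit, > 200000 nM, in this assay. Compound 3 thus stands at the same limit as compound 2, and the step that the two limits leave unreadable from compound 2 to compound 3 cannot be sized. Compound 4 `CCCN(CCC)c1ncc2c(n1)CCN(C(=O)c1cc(Cc3n[nH]c(=O)c4ccccc34)ccc1F)C2` differs from compound 3 by dipropylamino in place of (2-(dimethylamino)ethyl)(methyl)amino on an aromatic carbon. Going by the values given here, the only measured step at this carbon, a step that the two limits leave unreadable from compound 2 to compound 3, is unreadable since the limit of > 200000 nM in this assay, at which 2 of the 3 values shown sit, caps both ends, so no measured step bears usefully on the change to compound 4, and neither size nor direction can be anticipated in this assay beyond the scatter. Compound 4 is expected at 250000 nM in this assay, most probably again only a limit, within 60000 nM to 1000000 nM. The expected step is therefore a step that the limit leaves unreadable from compound 3 to compound 4.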

Compound 4, half-maximal inhibitory concentration: > 200000 nM
Compound 4: only a limit was reported; the forecaster's own chance of this, stated with the estimate: 75%; the middle value is on the limit's open side.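

Going by these compounds alone, no step among compound 2, compound 3 and compound 4 can be read, because all three stop at one assay limit: the limit of > 200000 nM in this assay, at which 3 of the 4 values shown sit. The compounds shown leave open which group on this aromatic carbon, if any, gives a readable value in this assay.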